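One group exchanged on compound 2: exposure in mice

A few compounds are considered here, and "the series" means these few. Any claim that something is new, unique, unknown or untested is made for them only; others in the source may bear on it.

Measured so far in an ADME assay on the whole organism for pharmacokinetics, with Mus musculus as the target, at a dose of 10 mg/kg by the oral route; on this read-out higher numbers stand for higher exposure at the dose given and lower numbers for lower exposure:
- compound 1 `CC/C(=C(/c1ccc(/C=C/C(=O)O)cc1)c1cccc2[nH]ncc12)c1ccccc1` gives 2800 ng.h/mL
- compound 2 `CC/C(=C(/c1ccc(/C=C/C(=O)O)cc1)c1ccc2[nH]ncc2c1)c1ccccc1Cl` gives 15000 ng.h/mL

Compound 2 at 15000 ng.h/mL holds the higher of the two numbers, and its gap to compound 1 lies beyond the usual scatter. These two compounds differ in more than one place, so that gap cannot be pinned on any single group.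

Compound 3 `CC/C(=C(/c1ccc(/C=C/C(=O)O)cc1)c1ccc2[nH]ncc2c1)c1ccc(C#N)cc1C` carries 4-cyano-2-methylphenyl in place of 2-chlorophenyl on a double-bonded chain carbon bound to a double-bonded chain carbon and a saturated chain carbon. For the measured compounds named here, no measured pair shows this exchange alone, so any expectation here is loose. The estimated 1.7-fold lower number from compound 2 to compound 3 (0.22 log units; within the scatter) is a small fall that stays within the usual scatter. For compound 3 the expected value is 9000 ng.h/mL with a wide estimated range from 3000 ng.h/mL to 25000 ng.h/mL around it.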

Compound 3, area under the concentration-time curve: 4300 ng.h/mL
Compound 3: middle estimate off by 2.1-fold (0.32 log units), on the high side; measured number inside the range.
By their numbers in this assay, from the lowest: compounds 1 and 3 (each within the scatter of the next); then compound 2.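

In this assay, the exchange of 2-chlorophenyl for 4-cyano-2-methylphenyl on a double-bonded chain carbon bound to a double-bonded chain carbon and a saturated chain carbon gives a 3.5-fold lower number from compound 2 to compound 3 (0.54 log units; beyond the scatter). For the compounds shown here, this is the first comparison here with only one place changed, so it shows that the aromatic group at this position can shift exposure in mice beyond the usual scatter, and that this exchange lowers it on the core shared by these two compounds. No measurement here gives a reason for the fall.

The exchange removes the chlorine and adds a methyl and a nitrile in one move, so a plain 2-methylphenyl or a 4-cyano-2-chlorophenyl at this place would be needed to tell which part carries the fall. On these data alone, whether the same exchange would lower exposure on the core of compound 1 also remains open.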